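This account rests on a few compounds, and the source may have more. Where it says the series, first, only, none or still open, it means among the compounds named here.

Compound 1 `C=CC[C@@H]1NC(=O)[C@@H](C)NC(=O)[C@@H]2Cc3ccc(OC)c(c3)Oc3ccc(cc3)C[C@@H](C(=O)N2C)N(C)C(=O)[C@H](C)NC(=O)[C@H](Cc2ccc(OC)cc2)N(C)C1=O` gives 38.9 nM
Compound 2 `CCC[C@@H]1NC(=O)[C@@H](C)NC(=O)[C@@H]2Cc3ccc(OC)c(c3)Oc3ccc(cc3)C[C@@H](C(=O)N2C)N(C)C(=O)[C@H](C)NC(=O)[C@H](Cc2ccc(OC)cc2)N(C)C1=O` gives 13.8 nM

For the measured compounds named here, both numbers come from a functional assay on P388 cells (Mus musculus) for cytotoxicity (on this read-out lower numbers stand for stronger inhibition and higher numbers for weaker inhibition), and compound 2 (13.8 nM) holds the lower of the two, with compound 1 (38.9 nM) as its only neighbour. Compound 3 `COc1ccc(C[C@H]2C(=O)N[C@@H](C)C(=O)N(C)[C@H]3Cc4ccc(cc4)Oc4cc(ccc4OC)C[C@@H](C(=O)N[C@H](C)C(=O)N[C@@H](CCCN=[N+]=[N-])C(=O)N2C)N(C)C3=O)cc1` keeps the core of compound 2 and differs from it in one place (azido in place of hydrogen on a saturated chain carbon, three bonds along the chain from a saturated ring carbon) so that propyl becomes 3-azidopropyl. Going by the values given here, the only measured step that bears on this change alters the same chain (a 2.8-fold lower number from compound 1 to compound 2 (0.45 log units; beyond the scatter)) and it is modest. Among the compounds with values here, no compound with an azido group has been measured yet, so the data give no firm direction. Within the data shown here, a step of similarly modest size is expected, leaning slightly towards a higher number, since compound 2 (13.8 nM) is the lower of only two values. The estimate therefore means a 1.8-fold higher number from compound 2 to compound 3 (0.26 log units; within the scatter) as the expected step, and with so little evidence its range stays wide. For compound 3 the expected value is 25 nM with a wide estimated range (7 nM to 90 nM).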

Compound 3, half-maximal inhibitory concentration: 35.5 nM
The estimate for compound 3 lay 1.4-fold (0.15 log units) below the measured number, and the stated range covers the measured number.
By their numbers in this assay, from the lowest: compound 2; then compounds 3 and 1 (each within the scatter of the next).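

On this assay, the azido group at the end of the propyl chain gives a modest loss of inhibition (a 2.6-fold higher number from compound 2 to compound 3 (0.41 log units; beyond the scatter)), so this chain position responds to a change at its far end as well as to the vinyl-to-ethyl change seen earlier. The 3-azidopropyl chain of compound 3 and the shorter, unsaturated chain of compound 1 cannot be told apart (a 1.1-fold lower number from compound 1 to compound 3 (0.04 log units; within the scatter)), which leaves the plain propyl chain of compound 2 with the lowest number of the three, beyond the scatter of both others. Nothing shown here explains why adding azido weakens inhibition, or why these two different chains end up level.

The compounds shown leave open whether azido itself matters or whether any added group at the chain end would give the same result, a question that a 3-aminopropyl chain or a chain ending in a carboxylic acid could help answer. They also leave open whether the plain chain has reached its best length at propyl, or whether a longer chain such as butyl would give a lower number still.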